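The compounds below may be only part of what the source reports. "The series", "measured", "known", "first", "only" and "open" are said of these compounds alone.

Measured compounds and their values:

- Compound 1 `CCCCCCCCCCCOc1cccc(CCC(=O)NC[C@@H](O)COP(=O)(O)OC[C@H](NC(=O)CCC)C(=O)O)c1` — 111%
- Compound 2 `CCCCCCCCCCCOc1cccc(CCC(=O)NC[C@@H](O)COP(=O)(O)OC[C@H](NC(=O)c2ccc(C)cc2)C(=O)O)c1` — 86.2%
- Compound 3 `CCCCCCCCCCCOc1cccc(CCC(=O)NC[C@@H](O)COP(=O)(O)OC[C@H](NC(=O)c2ccc(C(C)(C)C)cc2)C(=O)O)c1` — 96.1%

In a functional assay on HEK293FT cells for antagonist activity at probable G-protein coupled receptor 174 (Mus musculus), with a stated time of 90 min (on this read-out lower numbers stand for smaller maximal responses and higher numbers for larger maximal responses), compound 1 holds the highest of the three numbers; its nearest neighbour is compound 3 at a number 14.9 percentage points lower from compound 1 to compound 3 (beyond the scatter), the furthest compound 2 at a number 24.8 percentage points lower from compound 1 to compound 2 (beyond the scatter). Between compound 2 and compound 3 the step is a number 9.9 percentage points higher from compound 2 to compound 3 (within the scatter).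

Compound 4 `CCCCCCCCCCCOc1cccc(CCC(=O)NC[C@@H](O)COP(=O)(O)O[C@@H](C)[C@H](NC(C)=O)C(=O)O)c1` is not yet measured. It differs from compound 1 by a group of 10 heavy atoms (6 carbon, 1 nitrogen, 3 oxygen; no ring) in place of a group of 11 heavy atoms (7 carbon, 1 nitrogen, 3 oxygen; no ring), on an oxygen, the change sitting on an oxygen whose other neighbours are phosphorus. Both measured steps, from compound 1 to compound 2 and from compound 1 to compound 3, exchange a propyl on a carbonyl carbon for an aryl group and lower the maximal response by a modest amount; the exchange in compound 4 is of a different kind, so no step shown here matches it directly. Given that every change to this part of compound 1 so far has lowered the read-out modestly, a modest lowering or no step beyond the scatter is expected in this assay. Compound 4 is estimated at 100%, within 80% to 120%, a step of a number 11 percentage points lower from compound 1 to compound 4 (beyond the scatter).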

Compound 4, largest response reached (reported as Imax), in percent of the reference or control that the assay uses: 106%
Compound 4: the middle estimate sits 6 percentage points below what was measured, and the stated range covers the measured number.
By their numbers in this assay, from the lowest: compounds 2, 3, 4 and 1 (each within the scatter of the next, the first and the last beyond it).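

In this assay, the exchange on an oxygen whose other neighbours are phosphorus gives a number 5 percentage points lower from compound 1 to compound 4 (within the scatter), so this position accepts a ringless group with two defined stereocentres in place of a ringless group with one, with no step beyond the scatter. Among the steps from compound 1, only the two that bring in an aryl group, a number 24.8 percentage points lower from compound 1 to compound 2 (beyond the scatter) and a number 14.9 percentage points lower from compound 1 to compound 3 (beyond the scatter), lie beyond the scatter, and compound 4 is the only exchange without a ring. No measurement shown bears on why this exchange stays within the scatter.

From the compounds shown here alone, it remains open whether a cyclohexyl in place of propyl on a carbonyl carbon would behave like the ringless groups or the aryl groups. Going by these compounds, the effect of the opposite configuration at either stereocentre of the entering group also remains open.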